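This account rests on a few compounds, and the source may have more. Where it says the series, first, only, none or still open, it means among the compounds named here.

Compound 3 `Cc1cccc(C(=O)Nc2cccc(-c3oc4cc(-c5ccc(F)cc5)ccc4c(=O)c3O)c2)c1` was tested in a functional assay on HeLa cells (Homo sapiens) for antiproliferative activity, read by CCK-8 assay, with a stated time of 72 h (a lower number here means a stronger inhibitor, a higher number a weaker inhibitor), and gave 6650 nM. Among the three compounds measured it stands second highest: compound 1 `O=C(Nc1cccc(-c2oc3cc(-c4ccc(F)cc4)ccc3c(=O)c2O)c1)c1ccc(Cl)cc1` gives 3670 nM, and the step of a 1.8-fold higher number from compound 1 to compound 3 (0.26 log units; within the scatter) lies within the scatter, while compound 2 `O=C(Nc1cccc(-c2oc3cc(-c4ccc(F)cc4)ccc3c(=O)c2O)c1)c1ccc(F)cc1F` gives 10700 nM, and the step of a 1.6-fold lower number from compound 2 to compound 3 (0.21 log units; within the scatter) is also within the scatter. Among the measured compounds shown here, the only step beyond the scatter is a 2.9-fold higher number from compound 1 to compound 2 (0.46 log units; beyond the scatter). Compound 4 `COc1ccc(C(=O)Nc2cccc(-c3oc4cc(-c5ccc(F)cc5)ccc4c(=O)c3O)c2)c(F)c1` differs from compound 3 by 2-fluoro-4-methoxyphenyl in place of 3-methylphenyl on a carbonyl carbon. A fluorine on the amide-bearing ring also appears in compound 2, and a modest rise is expected because compound 2 gives 10700 nM. The step is therefore estimated as a 1.4-fold higher number from compound 3 to compound 4 (0.13 log units; within the scatter). Compound 4 is expected to give about 9000 nM, within a range of 3500 nM to 25000 nM.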

Compound 4, half-maximal inhibitory concentration: 16100 nM
The estimate for compound 4 lay 1.8-fold (0.25 log units) below the measured number; the range from low to high includes it.
By their numbers in this assay, from the lowest: compounds 1, 3, 2 and 4 (each within the scatter of the next, the first and the last beyond it).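

Replacing 3-methylphenyl with 2-fluoro-4-methoxyphenyl on this carbonyl carbon gives the first step from compound 3 that lies beyond the scatter (a 2.4-fold higher number from compound 3 to compound 4 (0.38 log units; beyond the scatter)), and the replacement of 4-chlorophenyl gives the largest step seen at this position (a 4.4-fold higher number from compound 1 to compound 4 (0.64 log units; beyond the scatter)). Methoxy in place of fluoro on an aromatic carbon, by contrast, stays within the scatter (a 1.5-fold higher number from compound 2 to compound 4 (0.18 log units; within the scatter)). No evidence is available to explain these steps. Still open, from the compounds shown here alone, is how a cyclohexyl or a pyridyl group on the same carbonyl carbon would read, and whether an amine on the aromatic ring would lower the number.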